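The source may report more compounds than this note shows. Statements on the series, on what has been measured and on what is new or still open speak of the compounds shown alone.

Measured so far:
Compound 1 `COc1ccc(C(=O)NCCCN2CCN(CCCNc3ccnc4cc(Cl)ccc34)CC2)cc1OC` — in an ADME assay on L6 cells (Rattus norvegicus) for cytotoxicity (a lower number here means a stronger inhibitor, a higher number a weaker inhibitor), compound 1 gives "not determined" (no result reported).
Compound 2 `O=C(NCCCN1CCN(CCCNc2ccnc3cc(Cl)ccc23)CC1)c1cc(F)cc(F)c1` — in this assay compound 2 gives 11600 nM.

The account follows the step from compound 1 to compound 3 `O=C(NCCCN1CCN(CCCNc2ccnc3cc(Cl)ccc23)CC1)c1ccc(Cl)c([N+](=O)[O-])c1`. Compound 1 carries no single number in this assay, so it cannot be placed on the scale; the only measured anchor in this set is compound 2, whose value is the sole fixed point. The change from compound 1 to compound 3 is 4-chloro-3-nitrophenyl in place of 3,4-dimethoxyphenyl on a carbonyl carbon. Cut one bond further out it reads as (3,4-dimethoxyphenyl)carbonyl to (4-chloro-3-nitrophenyl)carbonyl, with the rest of the shared core untouched.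

For the measured compounds named here, no step between measured compounds is available, and compound 1 itself has no value, so the expectation for compound 3 rests on the measured value of compound 2, which shares the whole core and differs only in the aryl group on the carbonyl carbon. Going by the values given here, with no step to lean on, no shift beyond the scatter in this assay is expected in either direction. Compound 3 is therefore expected to come out near 9000 nM, in the range 3000 nM to 30000 nM.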

Compound 3, half-maximal inhibitory concentration: 11300 nM
Compound 3: middle estimate off by 1.3-fold (0.10 log units), on the low side; measured number inside the range.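

In this assay, for the compounds shown here, the aryl group on a carbonyl carbon can now be compared between two measured compounds for the first time, and the step (a 1.0-fold lower number from compound 2 to compound 3 (0.01 log units; within the scatter)) shows that 4-chloro-3-nitrophenyl and 3,5-difluorophenyl cannot be told apart at this place. This is a single pair, so the finding holds for these two groups only, and the step that replaces 3,4-dimethoxyphenyl with 4-chloro-3-nitrophenyl cannot be read, since compound 1 carries no number. Nothing among the available data bears on why the two aryl groups give values within the scatter of each other.

Where compound 1, with its 3,4-dimethoxyphenyl group, would stand on this scale remains open, and so does whether the flat reading extends beyond these two aryl groups. The compounds shown also leave open what a carboxylic acid or an amine on the aryl ring would do, or what a longer chain between the carbonyl and the ring would do, in this assay.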